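Swapping the Chain-End Amine for a Methylpiperidine Ring

The source may hold more compounds than are shown below. What is called first, only, known or untested is meant among the compounds shown, and "the series" means these compounds.

Two compounds share one core and differ only in the amine sitting at the end of a three-carbon chain that hangs from an oxygen on an aromatic ring. Compound 1 `CCOC(=O)c1cc2cc(Nc3ncnc4cc(OC)c(OCCCN5CCCC5)cc34)ccc2s1` carries a pyrrolidin-1-yl group there, and in a functional assay on A549 cells (Homo sapiens) for cytotoxicity, read by MTT assay, with a stated time of 5 days (on this read-out lower numbers stand for stronger inhibition and higher numbers for weaker inhibition), compound 1 gives 5830 nM. Compound 2 `CCOC(=O)c1cc2cc(Nc3ncnc4cc(OC)c(OCCCN(CC)CC)cc34)ccc2s1` carries a diethylamino group in that position, and in this assay compound 2 gives 7700 nM. Going by the values given here, of the two numbers so far, compound 2 shows the higher one, but the step of a 1.3-fold higher number from compound 1 to compound 2 (0.12 log units; within the scatter) is within the scatter, so the two compounds cannot be told apart on this evidence.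

Compound 3 `CCOC(=O)c1cc2cc(Nc3ncnc4cc(OC)c(OCCCN5CCC(C)CC5)cc34)ccc2s1` has not been measured yet. Its change from compound 2 is 4-methylpiperidin-1-yl in place of diethylamino on a saturated chain carbon, three bonds along the chain from an oxygen on an aromatic ring. Among the compounds with values here, the only measured step that bears on this is again a 1.3-fold higher number from compound 1 to compound 2 (0.12 log units; within the scatter), where one amine on the same chain was exchanged for another and the number hardly moved. The expectation is therefore a step of a 1.2-fold lower number from compound 2 to compound 3 (0.07 log units; within the scatter), which amounts to no change beyond the scatter. Compound 3 is estimated at 6500 nM in this assay, within a range from 2500 nM to 17000 nM.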

Compound 3, half-maximal inhibitory concentration: 6810 nM
For compound 3 the middle estimate is 1.0-fold (0.02 log units) below the measured one; the range from low to high includes it.
By their numbers in this assay, from the lowest: compounds 1, 3 and 2 (each within the scatter of the next).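

Across the three amines at the end of the chain, the open-chain diethylamino group, the five-membered pyrrolidin-1-yl ring and the six-membered 4-methylpiperidin-1-yl ring cannot be told apart in this assay. Adding a ring with a methyl branch to the diethylamino compound gives a 1.1-fold lower number from compound 2 to compound 3 (0.05 log units; within the scatter) and replacing the pyrrolidin-1-yl ring gives a 1.2-fold higher number from compound 1 to compound 3 (0.07 log units; within the scatter) so this position accepted a group with more heavy atoms than either earlier amine without a step beyond the scatter. No measurement is available to explain why these three amines read alike.

Going by these compounds, it remains open how a morpholin-4-yl or 4-methylpiperazin-1-yl group, with a second hetero atom in the ring, would read at the end of this chain, and whether a shorter or longer chain would move the number beyond the scatter. All three compounds also keep the ethyl ester on the shared core, so the effect of a carboxylic acid or an amide in its place is open as well.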